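The compounds below may be only part of what the source reports. "The series", "measured", "known", "first", "only" and "open" are said of these compounds alone.

Three related compounds have been measured so far in a functional assay on HeLa cells (Homo sapiens) for antiproliferative activity, read by MTT assay, with a stated time of 48 h; a lower number here means a stronger inhibitor, a higher number a weaker inhibitor. Compound 1 (`Cc1cc2nc(NC(c3cn(-c4ccccc4)nc3-c3ccc([N+](=O)[O-])cc3)c3c(O)ccc4ccccc34)sc2cc1C`) gives 14700 nM, and compound 2 (`O=[N+]([O-])c1ccc(-c2nn(-c3ccccc3)cc2C(Nc2nc3ccccc3s2)c2c(O)ccc3ccccc23)cc1`) gives 6810 nM. Compound 3 (`Oc1ccc2ccccc2c1C(Nc1nc2ccc(Cl)cc2s1)c1cn(-c2ccccc2)nc1-c1ccc(I)cc1`) gives 12100 nM, a number within the usual scatter of each of the other two.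

The compound still to be measured is compound 4 (`O=[N+]([O-])c1ccc(-c2nn(-c3ccccc3)cc2C(Nc2nc3ccc(Cl)cc3s2)c2c(O)ccc3ccccc23)cc1`). It differs from compound 3 in one place: nitro in place of iodo on an aromatic carbon. Put another way, the 4-iodophenyl group of compound 3 becomes the 4-nitrophenyl group of compound 4, and the rest of the structure stays the same.

Among the measured compounds shown here, no measured pair shows this exchange directly. For the measured compounds named here, the only measured step, a 2.2-fold lower number from compound 1 to compound 2 (0.33 log units; beyond the scatter), is modest and concerns the group on the amine nitrogen, so it bears on this change only indirectly. It does show that compounds with the 4-nitrophenyl group can lie on either side of compound 3, since compound 1 has 14700 nM and compound 2 has 6810 nM. On that evidence, no step beyond the scatter is expected in this assay. The expected change is small, a 1.2-fold lower number from compound 3 to compound 4 (0.08 log units; within the scatter). Compound 4 is estimated at 10000 nM, with an expected range from 4500 nM to 22000 nM.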

Compound 4, half-maximal inhibitory concentration: 13400 nM
Compound 4: the middle estimate sits 1.3-fold (0.13 log units) below what was measured; low and high end bracket the measured number.
By their numbers in this assay, from the lowest: compounds 2, 3, 4 and 1 (each within the scatter of the next, the first and the last beyond it).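

In this assay, the first direct view of this exchange on the shared core gives a 1.1-fold higher number from compound 3 to compound 4 (0.04 log units; within the scatter), so the 4-iodophenyl and 4-nitrophenyl groups cannot be told apart here, even though iodo brings one heavy atom and no hydrogen-bond acceptors while nitro brings three heavy atoms and two acceptors. The new compound also links to the earlier ones through the group on the amine nitrogen: chloro in place of hydrogen on an aromatic carbon gives a 2.0-fold higher number from compound 2 to compound 4 (0.29 log units; within the scatter), and 6-chloro-1,3-benzothiazol-2-yl in place of 5,6-dimethyl-1,3-benzothiazol-2-yl gives a 1.1-fold lower number from compound 1 to compound 4 (0.04 log units; within the scatter), both printed as within the usual scatter. No measurement among these compounds offers an explanation for how little the number moves at this position.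

Still open, from the compounds shown here alone, is whether an amine or a carboxylic acid in place of iodo or nitro on this phenyl ring would move the number beyond the scatter. Among the compounds shown here, the exchange is also seen only with the 6-chloro-1,3-benzothiazol-2-yl group on the amine nitrogen, so whether it behaves the same way with other groups there remains unknown.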